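A few compounds are considered here, and "the series" means these few. Any claim that something is new, unique, unknown or untested is made for them only; others in the source may bear on it.

Of the compounds shown here, three sharing one core have been tested for how strongly they switch on the 5-hydroxytryptamine receptor 4 in a functional assay on CHO cells for agonist activity at 5-hydroxytryptamine receptor 4 (Homo sapiens), read by a luciferase reporter and cAMP accumulation, with a stated time of 4 h; on this read-out lower numbers stand for an effect already at smaller amounts and higher numbers for an effect only at larger amounts of compound. Compound 1 `CC(C)c1nc(C(=O)NCC2CCN(C3CCOCC3)CC2)c2ccccn12` gives 11 nM. Compound 2 `CC(C)c1nc(C(=O)NCC2CCN(C3CCC3)CC2)c2ccccn12` gives 9.8 nM. These two differ in one place only, the change being (oxan-4-yl in place of cyclobutyl on an amine nitrogen in a ring). The step that this change made is a 1.1-fold higher number from compound 2 to compound 1 (0.05 log units; within the scatter), so the two compounds cannot be told apart on this read-out.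

Compound 3 `CC(C)c1nc(C(=O)NC[C@@H]2[C@H]3CN(C4CCC4)C[C@@H]23)c2ccccn12` gives 18 nM. Its core is not the same as that of compound 2, and the difference between the two cores is not broken down here; the two values lie close together, and nothing more can be read from them.

Compound 4 `CC(C)c1nc(C(=O)NC[C@@H]2[C@H]3CN(C4CCOCC4)C[C@@H]23)c2ccccn12` has not yet been measured. It differs from compound 3 in one place, the change being (oxan-4-yl in place of cyclobutyl on an amine nitrogen in a ring). Going by the values given here, this is the same kind of change as the one from compound 2 to compound 1, but the place is not the same: there the amine nitrogen sits in a six-membered non-aromatic ring with three ring bonds from the ring atom that bears a large group, while here it sits in a five-membered non-aromatic ring that is part of a fused or bridged system of two rings. Because the earlier step was a 1.1-fold higher number from compound 2 to compound 1 (0.05 log units; within the scatter), the step from compound 3 to compound 4 is expected to be about as small, a 1.1-fold higher number from compound 3 to compound 4 (0.05 log units; within the scatter). Compound 4 is therefore estimated at 20 nM, likely between 9 nM and 45 nM.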

Compound 4, half-maximal effective concentration: 20.7 nM
Compound 4: the middle estimate sits 1.0-fold (0.01 log units) below what was measured, and the stated range covers the measured number.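

In this assay, putting oxan-4-yl in place of cyclobutyl on the amine nitrogen gives a 1.2-fold higher number from compound 3 to compound 4 (0.06 log units; within the scatter), so on the core of compound 3, as on the core of compound 2, the read-out does not tell the two groups apart. The swap therefore behaves alike on both cores, with its nitrogen in a six-membered ring in one and in a five-membered ring within a fused or bridged system of two rings in the other: the same change on two cores in this assay, a 1.1-fold higher number (0.05 log units; within the scatter) from compound 2 to compound 1 and a 1.2-fold higher number (0.06 log units; within the scatter) from compound 3 to compound 4, 1.0-fold (0.01 log units) apart, within the scatter of two such steps. Going by these compounds alone, this is only two pairs in one assay, and both steps are so small that they show only that this swap leaves the number within the scatter on these two cores, not that larger steps from other changes would carry from one core to the other, nor why the swap makes so little difference.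

The compounds shown leave open whether a group of another kind on this nitrogen, such as a plain methyl, a longer chain or a chain ending in a carboxylic acid, would also leave the number in place on either core. They also leave open whether the match between the two steps would hold on a third core, or for a change made elsewhere in the molecule, such as at the isopropyl group.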